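The source may report more compounds than this note shows. Statements on the series, on what has been measured and on what is new or still open speak of the compounds shown alone.

Measured compounds:
compound 1, `Brc1cn2ccnc2c(-c2ccc3ncn(C4CCCCC4)c3c2)n1`: 67.7%
compound 2, `O=Cc1ccc(-c2cn3ccnc3c(-c3ccc4ncn(C5CCCCC5)c4c3)n2)cc1`: 3.69%
compound 3, `Brc1ccc(-c2cn3ccnc3c(-c3ccc4ncn(C5CCCCC5)c4c3)n2)cc1`: 23.3%

In a functional assay on KM12 cells (Homo sapiens) for inhibition, read by sulforhodamine B assay, with a stated time of 48 h, tested at 10 uM (a lower number here means less inhibition, a higher number more inhibition at the concentration tested (going by the name of the read-out)), compound 3 stands second highest of the three numbers. Its nearest neighbour is compound 2, the step being a number 19.6 percentage points higher from compound 2 to compound 3 (beyond the scatter); its furthest is compound 1, with a number 44.4 percentage points lower from compound 1 to compound 3 (beyond the scatter) between them.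

The next compound is compound 4, `FC(F)(F)c1cccc(-c2cn3ccnc3c(-c3ccc4ncn(C5CCCCC5)c4c3)n2)c1`. The change from compound 3 is 3-(trifluoromethyl)phenyl in place of 4-bromophenyl on an aromatic carbon.

Two kinds of step bear on this. The exchange of bromo for an aryl group, seen in a number 64 percentage points lower from compound 1 to compound 2 (beyond the scatter) and a number 44.4 percentage points lower from compound 1 to compound 3 (beyond the scatter), was large in both cases. The swap of one aryl group for another, seen in a number 19.6 percentage points higher from compound 2 to compound 3 (beyond the scatter), was modest. Compound 4 keeps an aryl group at this position, so the relevant precedent is the modest aryl-to-aryl step; its direction for a 3-(trifluoromethyl)phenyl group cannot be read from the data.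

Compound 4 is therefore expected to give 18%, between 0% and 42%. The expected step is a number 5.3 percentage points lower from compound 3 to compound 4 (within the scatter), not clearly beyond the scatter.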

Compound 4, a percentage reported as inhibition, at one concentration (the size of the read-out at that concentration, not a potency): 1.25%
Beside the measured number, compound 4's estimate is 16.8 percentage points above it, and the stated range covers the measured number.
By their numbers in this assay, from the lowest: compounds 4 and 2 (each within the scatter of the next); then compound 3; then compound 1.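

In this assay, the change to 3-(trifluoromethyl)phenyl gave a number 22.1 percentage points lower from compound 3 to compound 4 (beyond the scatter), so a swap of one aryl group for another at this position can lower the number as well as raise it. Among these compounds, the 3-(trifluoromethyl)phenyl and 4-formylphenyl groups could not be told apart, with a number 2.4 percentage points lower from compound 2 to compound 4 (within the scatter), leaving 4-bromophenyl as the only aryl group here that stands clear of another. The bromo of compound 1 also remains well separated from this new aryl group, with a number 66.5 percentage points lower from compound 1 to compound 4 (beyond the scatter). Nothing available explains these differences. Going by these compounds, it remains open whether the trifluoromethyl group itself or its place on the phenyl ring carries the change, which 3-bromophenyl or 4-(trifluoromethyl)phenyl could separate, and how an amine or a carboxylic acid on the phenyl ring would compare.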